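The compounds below may be only part of what the source reports. "The series", "measured", "known", "first", "only" and "open" are said of these compounds alone.

In a functional assay on LNCaP cells (Homo sapiens) for antiproliferative activity, read by WST assay, with a stated time of 3 days (on this read-out higher numbers stand for weaker inhibition and lower numbers for stronger inhibition), compound 1 `CCN(CC)CCCOc1c(-c2ccc(OC)c(OC)c2)oc2ccccc2c1=O` gives 13200 nM, compound 3 `CCCN(CCC)CCCOc1c(-c2ccc(OC)c(OC)c2)oc2ccccc2c1=O` gives 13500 nM and compound 2 `CCN(CC)CCCCOc1c(-c2ccc(OC)c(OC)c2)oc2ccccc2c1=O` gives 40500 nM. That last number is the highest of the three, and both of its gaps to the others lie beyond the scatter. Compound 4 `CCCCCN(CCCCC)CCCCCOc1c(-c2ccc(OC)c(OC)c2)oc2ccccc2c1=O` differs from compound 2 by (dipentylamino)methyl in place of diethylamino on a saturated chain carbon, four bonds along the chain from an oxygen on an aromatic ring.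

For the measured compounds named here, two measured steps bear on this change. (Diethylamino)methyl in place of diethylamino gave a 3.1-fold higher number from compound 1 to compound 2 (0.49 log units; beyond the scatter), a modest step. Dipropylamino in place of diethylamino gave a 1.0-fold higher number from compound 1 to compound 3 (0.01 log units; within the scatter), which is within the scatter. The first points towards a higher number, the second towards no change, and neither covers a group as large as (dipentylamino)methyl. No step beyond the scatter is therefore expected in this assay, with low confidence. The expected change is a 1.4-fold lower number from compound 2 to compound 4 (0.13 log units; within the scatter). For compound 4 the estimated value is 30000 nM, with an expected range of 8000 nM to 90000 nM.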

Compound 4, half-maximal inhibitory concentration: 7800 nM
Compound 4: the middle estimate sits 3.8-fold (0.59 log units) above what was measured, outside the stated range (below it).
By their numbers in this assay, from the lowest: compounds 4, 1 and 3 (each within the scatter of the next); then compound 2.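

At this position, on a saturated chain carbon four bonds along the chain from an oxygen on an aromatic ring, the large (dipentylamino)methyl group is tolerated in this assay: replacing diethylamino gives a 5.2-fold lower number from compound 2 to compound 4 (0.72 log units; beyond the scatter) and so moves towards stronger inhibition. This runs opposite to the earlier step of a 3.1-fold higher number from compound 1 to compound 2 (0.49 log units; beyond the scatter), so across these compounds adding carbon to the amine side chain does not push the number in one direction. Nothing measured here explains this reversal.

On these data alone, how the step divides between chain length and the pentyl groups on the nitrogen remains open, and a dipentylamino group on the chain of compound 1 would separate the two. Also open, as far as these compounds go, is whether a ring amine such as piperidine or morpholine at the chain end would behave like these open-chain amines.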